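This account rests on a few compounds, and the source may have more. Where it says the series, first, only, none or still open, it means among the compounds named here.

In a functional assay on HepG2 cells (Homo sapiens) for cytotoxicity, read by MTT assay, with a stated time of 72 h (a higher number here means a weaker inhibitor, a lower number a stronger inhibitor), three compounds sharing one core differ in a single place. Compound 1 `CN1CCN(c2ccc(Nc3ncc4nc(Nc5cccc([N+](=O)[O-])c5)n(C5CCCC5)c4n3)cc2)CC1` gives > 5000 nM as its reading, which is a limit and not a number. Compound 3 `CN1CCN(c2ccc(Nc3ncc4nc(Nc5ccc(Br)cc5)n(C5CCCC5)c4n3)cc2)CC1` gives > 5000 nM as its reading, again a limit and not a number. Among the measured compounds shown here, compound 2 `Cc1cccc(Nc2nc3cnc(Nc4ccc(N5CCN(C)CC5)cc4)nc3n2C2CCCC2)c1` gives 4700 nM as the only actual number of the three.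

The account now moves to compound 4 `CN1CCN(c2ccc(Nc3ncc4nc(Nc5cccc(C(=O)Nc6ccc(Cl)cc6)c5)n(C5CCCC5)c4n3)cc2)CC1` which differs from compound 2 by having (4-chlorophenyl)carbamoyl in place of methyl on an aromatic carbon with the new group meta to a large group.

For the measured compounds named here, three measured steps bear on this. Methyl in place of nitro gave an at least 1.0-fold lower number from compound 1 to compound 2 (0.02 log units; that floor lies within the scatter) in this series. The change to 4-bromophenyl gave an at least 1.0-fold higher number from compound 2 to compound 3 (0.02 log units; that floor lies within the scatter) in the same series, and the remaining pair gave a step that the two limits leave unreadable from compound 1 to compound 3 as a step of no readable size. These steps stay small or unreadable because of the limit of > 5000 nM in this assay, at which 2 of the 3 values shown sit, in this series. None of them introduces a group like the one entering here, so they offer no measured size for it.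

On that footing no change beyond the scatter is expected, and the estimate amounts to a 1.2-fold lower number from compound 2 to compound 4 (0.07 log units; within the scatter) as the expected step. A reading reported only as a limit would also fit this expectation. In this assay the estimated value for compound 4 is 4000 nM with an expected range from 1500 nM to 7000 nM overall.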

Compound 4, half-maximal inhibitory concentration: > 5000 nM
Compound 4 was reported as a limit (the forecaster's own chance of this, stated with the estimate: 55%); middle value at least 1.2-fold (0.09 log units) away from the limit.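

In this assay the reading of compound 4 is a limit and not a number, so this aromatic carbon, meta to a large group, now carries a (4-chlorophenyl)carbamoyl, with its six-membered aromatic ring, hydrogen-bond donor and hydrogen-bond acceptor, and still yields no measurable number. Among the compounds shown here, the only readable step is an at least 1.0-fold higher number from compound 2 to compound 4 (0.02 log units; that floor lies within the scatter), which fixes a floor and not a size, while the step between the limits of compound 1 and compound 4 cannot be read. The series therefore shows no gain from this much larger group, but any loss stays hidden because the readings stop at a limit: the limit of > 5000 nM in this assay, at which 3 of the 4 values shown sit.

As far as these compounds go, how far compound 1, compound 3 and compound 4 truly lie from compound 2 remains open, and so does whether the amide link or the 4-chlorophenyl ring matters more. From the compounds shown here alone, it is also open whether an amine or a carboxylic acid on this same aromatic carbon would give a reading that is an actual number.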